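A formyl group replaces a chain end known only by limits

A few compounds are considered here, and "the series" means these few. Any claim that something is new, unique, unknown or untested is made for them only; others in the source may bear on it.

Compound 1 `C=C[C@@](C)(/C=C/c1ccc(O)cc1)CC/C=C/C#N`: > 49000 nM
Compound 2 `C=C[C@@](C)(/C=C/c1ccc(O)cc1)CC/C=C(C)/C=N/N`: > 49000 nM

Neither entry is a number; both are limits. In a functional assay on Jurkat cells (Homo sapiens) for cytotoxicity, with a stated time of 72 h (a lower number here means that less compound is needed, a higher number that more compound is needed for the effect), compound 1 gives > 49000 nM, which is a limit. In this assay compound 2 gives > 49000 nM, which is also a limit. Compound 2 therefore has no exact position on the scale, and the evidence so far consists of the limit of > 49000 nM in this assay, at which 2 of the 2 values shown sit.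

The next structure is compound 3 `C=C[C@@](C)(/C=C/c1ccc(O)cc1)CC/C=C(\C)C=O`, and the change is a group of 2 heavy atoms (1 carbon, 1 oxygen; no ring) in place of a group of 3 heavy atoms (1 carbon, 2 nitrogen; no ring), on a double-bonded chain carbon bound to a double-bonded chain carbon and a saturated chain carbon. The formyl group sits on a double-bonded chain carbon bound to a double-bonded chain carbon and a saturated chain carbon.

Among the measured compounds shown here, the only measured step that bears on this change is a step that the two limits leave unreadable from compound 1 to compound 2. It gives no size to carry over, so any expectation for this assay remains loose. Compound 3 may well stay at the limit, and a modest move towards less compound needed is the most that is expected. The estimated step is an at least 1.2-fold lower number from compound 2 to compound 3 (0.08 log units; that floor lies within the scatter). The estimate for compound 3 is 40000 nM, with an expected range of 12000 nM to 80000 nM.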

Compound 3, half-maximal effective concentration: > 49000 nM
Compound 3: a limit, no number; the forecaster's own chance of this, stated with the estimate: 55%; middle value at least 1.2-fold (0.08 log units) away from the limit.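

In this assay compound 3 gives > 49000 nM, which is again a limit and not a number, so no step can be read among compound 1, compound 2 and compound 3. The compounds shown leave open where any of the three stands on the scale, and whether the formyl group changes the concentration needed at all, with the evidence still being: the limit of > 49000 nM in this assay, at which 3 of the 3 values shown sit.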